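Nitro for methoxy in the aromatic series

The source may hold more compounds than are shown below. What is called first, only, known or untested is meant among the compounds shown, and "the series" means these compounds.

- compound 1 `O=C(OCc1cn(-c2ccc(F)cc2)nn1)[C@@H]1CCCN1`: 309000 nM
- compound 2 `Cc1ccc(-n2cc(COC(=O)[C@@H]3CCCN3)nn2)cc1`: 421000 nM
- compound 3 `COc1ccc(-n2cc(COC(=O)[C@@H]3CCCN3)nn2)cc1`: 218000 nM

In an ADME assay on THP-1 cells (Homo sapiens) for cytotoxicity, read by MTT assay, with a stated time of 24 h (on this read-out lower numbers stand for stronger inhibition and higher numbers for weaker inhibition), compound 3 gives 218000 nM, which is not separated from the other two compounds by more than the scatter. The next compound, compound 4 `O=C(OCc1cn(-c2ccc([N+](=O)[O-])cc2)nn1)[C@@H]1CCCN1`, carries nitro in place of methoxy on an aromatic carbon, para to a large group: nitro in place of methoxy on an aromatic carbon. Three measured exchanges on an aromatic carbon bear on this change: a 1.4-fold lower number from compound 1 to compound 3 (0.15 log units; within the scatter), a 1.9-fold lower number from compound 2 to compound 3 (0.29 log units; within the scatter) and a 1.4-fold higher number from compound 1 to compound 2 (0.13 log units; within the scatter). All three stay within the scatter. Among the compounds with values here, no nitro compound has been measured, so these fluoro, methyl and methoxy exchanges are only an indirect guide, and a wider range is warranted. In this assay no step beyond the scatter is expected, and the estimated step is a 1.2-fold higher number from compound 3 to compound 4 (0.09 log units; within the scatter). For compound 4 the estimated value is 270000 nM, with an expected range of 120000 nM to 520000 nM.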

Compound 4, half-maximal inhibitory concentration: 344000 nM
Compound 4: the middle estimate sits 1.3-fold (0.11 log units) below what was measured; the measured number falls inside the stated range.
By their numbers in this assay, from the lowest: compounds 3, 1, 4 and 2 (each within the scatter of the next).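

Nitro on this aromatic carbon, para to a large group, stays within the scatter of all three earlier groups in this assay: methoxy (a 1.6-fold higher number from compound 3 to compound 4 (0.20 log units; within the scatter)), methyl (a 1.2-fold lower number from compound 2 to compound 4 (0.09 log units; within the scatter)) and fluoro (a 1.1-fold higher number from compound 1 to compound 4 (0.05 log units; within the scatter)). Even the exchange of methoxy for nitro, which adds a heavy atom and a hydrogen-bond acceptor, does not separate compound 4 from compound 3. Across the four compounds shown, no exchange at this position moves the number beyond the scatter.

Open, on these data alone, is whether an amine or a carboxylic acid in place of nitro would give a step beyond the scatter. Also open, as far as these compounds go, is whether a change in the shared core, rather than on this aromatic carbon, would do so. No measured evidence accompanies these numbers to account for them.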